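The source may report more compounds than this note shows. Statements on the series, on what has been measured and on what is new or still open speak of the compounds shown alone.

Working notes on the series. In a functional assay on TSGH cells (Homo sapiens) for inhibition, with a stated time of 72 h (on this read-out higher numbers stand for weaker inhibition and lower numbers for stronger inhibition), compound 1 `COc1cc(C(=O)n2ccc3ccccc32)cc(OC)c1OC` gives 8400 nM, while compound 2 `COc1cc(C(=O)c2ccc3c(ccn3C)c2)cc(OC)c1OC` gives 13.4 nM. Compound 2 therefore holds the lower of the two numbers, and its gap to compound 1 lies beyond the scatter. The two compounds do not differ in one place only, so this gap is recorded here simply as what the two values show.

Compound 3 `COc1cc(C(=O)c2ccc3c(ccn3CO)c2)cc(OC)c1OC` departs from compound 2 in a single place, hydroxy in place of hydrogen on a saturated chain carbon bound to an aromatic nitrogen, which reads as methyl to hydroxymethyl. Among the measured compounds shown here, no measured pair covers a change at this place, so the expectation has only compound 2, at 13.4 nM, as its anchor. In this assay, the expected step of a 2.6-fold higher number from compound 2 to compound 3 (0.42 log units; beyond the scatter) is a modest rise in the number, meaning somewhat weaker inhibition, and it is expected to lie only slightly beyond the scatter. For compound 3 the estimated value is 35 nM, with an expected range of 12 nM to 130 nM.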

Compound 3, half-maximal inhibitory concentration: 43 nM
The estimate for compound 3 lay 1.2-fold (0.09 log units) below the measured number, and the stated range covers the measured number.
By their numbers in this assay, from the lowest: compound 2; then compound 3; then compound 1.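

In this assay, among the compounds shown here, methyl to hydroxymethyl on a saturated chain carbon bound to an aromatic nitrogen gives a 3.2-fold higher number from compound 2 to compound 3 (0.51 log units; beyond the scatter) and is the first step that can be read at a single place. This position therefore tolerates hydroxy in place of hydrogen at a modest cost: inhibition is weaker but far from lost, with compound 3 still at 43 nM in this one cellular read-out. Nothing available here accounts for the size of this step.

The compounds shown leave open whether the modest rise is specific to hydroxy or would follow from other groups at this place, such as an amine in aminomethyl, the ether in methoxymethyl, a carboxylic acid or a longer chain such as hydroxyethyl. With a single step at this position, they also leave open whether the same change would give a similar step on another core, or whether the hydrogen of compound 2 on this chain carbon can be replaced by something smaller, such as fluorine, with a different result.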